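Swapping Benzyl for Tert-Butyl on a Triazole Nitrone

A few compounds are considered here, and "the series" means these few. Any claim that something is new, unique, unknown or untested is made for them only; others in the source may bear on it.

Compound 1 `CCCCCCCCCCn1cc(/C=[N+](\[O-])Cc2ccccc2)nn1` carries a decyl chain on its core and a benzyl group on a double-bonded nitrogen. In a functional assay on COLO 205 cells (Homo sapiens) for inhibition, read by MTT assay, with a stated time of 24 h (on this read-out higher numbers stand for weaker inhibition and lower numbers for stronger inhibition), compound 1 reaches only the limit of > 100000 nM, which is a limit and not a number. Compound 3 `CCCCCCCCCCn1cc(/C=[N+](\[O-])C(C)(C)C)nn1` differs from it by tert-butyl in place of benzyl on a double-bonded nitrogen. In this assay compound 3 gives 22100 nM. That is an at least 4.5-fold lower number from compound 1 to compound 3 (0.65 log units; beyond the scatter). The true size of this step is open, because of the limit of > 100000 nM in this assay, at which 2 of the 3 values shown sit.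

Compound 2 `[O-]/[N+](=C\c1cn(CCC(F)(F)C(F)(F)C(F)(F)C(F)(F)C(F)(F)C(F)(F)F)nn1)Cc1ccccc1` also carries a benzyl group on the double-bonded nitrogen; the difference between its core and the core of compound 1 is not broken down here. In this assay compound 2 sits at the limit of > 100000 nM, again a limit rather than a number. Compound 4 `CC(C)(C)/[N+]([O-])=C/c1cn(CCC(F)(F)C(F)(F)C(F)(F)C(F)(F)C(F)(F)C(F)(F)F)nn1` differs from compound 2 by tert-butyl in place of benzyl on a double-bonded nitrogen, the same change, as both places are described in the same words. In this assay the expected step is an at least 2.8-fold lower number from compound 2 to compound 4 (0.45 log units; beyond the scatter), set beside the measured one, and it rests on compound 3 and its 22100 nM. In this assay compound 4 is estimated at 35000 nM, between 12000 nM and 100000 nM.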

Compound 4, half-maximal inhibitory concentration: 9500 nM
Estimate against measurement, compound 4: 3.7-fold (0.57 log units) above, outside the stated range (below it).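

In this assay, tert-butyl in place of benzyl on a double-bonded nitrogen again gives a lower number, here an at least 10-fold lower number from compound 2 to compound 4 (1.02 log units; beyond the scatter), so the direction of the change carries over from the core of compound 1 to the core of compound 2. This does not show that the change is worth the same amount on each core: the same change on two cores in this assay, an at least 4.5-fold lower number (0.65 log units; beyond the scatter) from compound 1 to compound 3 and an at least 10-fold lower number (1.02 log units; beyond the scatter) from compound 2 to compound 4; the limit leaves it open whether they differ. Neither step has a known true size, only a smallest possible one, because each starts from a limit of the assay: the limit of > 100000 nM in this assay, at which 2 of the 4 values shown sit.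

Only two cores are shown, so it stays open how the change would fare on a core with a shorter chain, or with an amine in place of the chain. Also open, from the compounds shown here alone, is whether a different group on the double-bonded nitrogen, such as methyl or cyclohexyl, would give a lower number than tert-butyl in this assay.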